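Piperazine aryl swap: dichlorophenyl to fluorophenyl

This account rests on a few compounds, and the source may have more. Where it says the series, first, only, none or still open, it means among the compounds named here.

Within the data shown here, compound 1 `Cc1nc(-c2ccccc2)c(C(=O)N2CCN(c3ccc(Cl)c(Cl)c3)CC2)o1` holds the lowest number of the two measured so far: in a functional assay on HL-60 cells (Homo sapiens) for inhibition, read by MTT assay, with a stated time of 72 h (on this read-out lower numbers stand for stronger inhibition and higher numbers for weaker inhibition), compound 1 gives 124 nM, while compound 2 `CCc1nc(-c2cccc(F)c2)c(C(=O)N2CCN(c3cccc(Cl)c3)CC2)o1` gives 317 nM, a difference beyond the usual scatter. Compound 3 `Cc1nc(-c2ccccc2)c(C(=O)N2CCN(c3cccc(F)c3)CC2)o1` differs from compound 1 in one place: 3-fluorophenyl in place of 3,4-dichlorophenyl on an amine nitrogen in a ring. Among the measured compounds shown here, no step of this exact kind has been measured, so the direction rests on the two numbers above only. The expectation is a moderate loss, a 2.8-fold higher number from compound 1 to compound 3 (0.45 log units; beyond the scatter), and compound 3 is estimated at 350 nM, within 150 nM to 900 nM.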

Compound 3, half-maximal inhibitory concentration: 45 nM
Compound 3: middle estimate off by 7.8-fold (0.89 log units), on the high side, outside the stated range (below it).
By their numbers in this assay, from the lowest: compound 3; then compound 1; then compound 2.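

In this assay, 3-fluorophenyl in place of 3,4-dichlorophenyl on an amine nitrogen in a ring gives a 2.8-fold lower number from compound 1 to compound 3 (0.44 log units; beyond the scatter) on the shared core. At this position, then, the 3,4-dichlorophenyl group is not needed for a low number, and the smaller aryl group does better. No measurement at hand accounts for the direction of this step.

Among these compounds, the single step changes both the halogen and the substitution pattern, so it cannot show which of the two matters. A plain phenyl or a 3-methoxyphenyl at this place on the core of compound 3 remains an open comparison.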